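Terminal amine variation: compound 1 to compound 4

This account rests on a few compounds, and the source may have more. Where it says the series, first, only, none or still open, it means among the compounds named here.

Measured in a functional assay on UMUC3 cells (Homo sapiens) for antiproliferative activity, read by MTT assay, with a stated time of 72 h; on this read-out higher numbers stand for weaker inhibition and lower numbers for stronger inhibition:
- compound 1 `CCN(C)C(=N)NC(=N)Nc1ccc(C(F)(F)F)cc1`: 6900 nM
- compound 2 `CC(C)NC(=N)NC(=N)Nc1ccc(F)c(F)c1`: 25000 nM
- compound 3 `CC(C)CNC(=N)NC(=N)Nc1ccc(F)cc1F`: 17300 nM

Of the three measured compounds, compound 1 gives the lowest number, 6900 nM. Its nearest neighbour is compound 3 at 17300 nM, a gap that lies beyond the usual scatter, and the furthest is compound 2 at 25000 nM, also beyond the scatter. Compound 1 therefore stands apart from the other two on the numbers shown; no single-point step between any of the measured compounds is available, so no step size has yet been established within the series.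

Compound 4 `CCN(CC)C(=N)NC(=N)Nc1ccc(C(F)(F)F)cc1` differs from compound 1 in one place: methyl in place of hydrogen on a saturated chain carbon bound to an amine nitrogen. Seen one bond further out, ethyl(methyl)amino becomes diethylamino. For the measured compounds named here, nothing among the measured compounds tests a change of this kind, so the expectation rests on the small size of the change alone. The step is expected to be small, a 1.0-fold higher number from compound 1 to compound 4 (0.01 log units; within the scatter), in no firm direction and not beyond the scatter. Compound 4 is estimated at 7000 nM, within a range from 3000 nM to 16000 nM.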

Compound 4, half-maximal inhibitory concentration: 4900 nM
Compound 4: the middle estimate sits 1.4-fold (0.15 log units) above what was measured; the range from low to high includes it.
By their numbers in this assay, from the lowest: compounds 4 and 1 (each within the scatter of the next); then compounds 3 and 2 (each within the scatter of the next).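

In this assay, for the compounds shown here, the change from ethyl(methyl)amino to diethylamino gives a 1.4-fold lower number from compound 1 to compound 4 (0.15 log units; within the scatter), the only step so far between compounds that differ in one place, and it stays within the usual scatter, so compound 1 and compound 4 cannot be ranked against each other. Going by these compounds alone, at this place, on a saturated chain carbon bound to an amine nitrogen, the extra methyl therefore leaves the number indistinguishable from that of the parent, something the earlier compounds could not show because none of them pairs up in this way. Nothing measured on these compounds offers an explanation for this result.

Still open, going by these compounds, is how much larger the terminal amine can become, since a longer chain such as dipropylamino would test whether the flat step continues, while an unsubstituted amino group would test the opposite direction. Within the data shown here, also open is whether the same step holds with the fluorine substituents of compound 2 and compound 3 in place of trifluoromethyl, as no pair yet separates the terminal amine from the aryl substituents.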